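The compounds below may be only part of what the source reports. "The series", "measured", "known", "first", "only" and "open" are said of these compounds alone.

For the measured compounds named here, compound 3 `CCCCCCCc1nc(N)n(CC(=O)Nc2ccc(C)cc2)c1-c1ccccc1Br` gives 5200 nM in a functional assay on A-375 cells (Homo sapiens) for antiproliferative activity, read by MTT assay, with a stated time of 48 h (a higher number here means a weaker inhibitor, a lower number a stronger inhibitor), the second highest of the three numbers so far. Compound 2 `CCCCCCc1nc(N)n(CC(=O)Nc2ccc(C)cc2)c1-c1ccccc1Br` gives 5100 nM, and the step of a 1.0-fold higher number from compound 2 to compound 3 (0.01 log units; within the scatter) shows the two chain lengths behave alike. Compound 1 `Nc1nc(CC2CCCCC2)c(-c2ccccc2Br)n1CC(=O)Nc1ccccc1` gives 40600 nM, the highest number. Compound 4 `Cc1ccc(NC(=O)Cn2c(N)nc(CC3CCCCC3)c2-c2ccccc2Br)cc1` introduces (cyclohexyl in place of hexyl on a saturated chain carbon bound to an aromatic carbon), so it carries the cyclohexylmethyl of compound 1 together with the methyl-bearing anilide of compound 3. Going by the values given here, no measured step tests this ring-for-chain exchange on its own; compound 1 differs from compound 4 in the anilide methyl and from compound 3 in both places. The estimate therefore leans toward a weaker inhibitor, with the step of a 2.9-fold higher number from compound 3 to compound 4 (0.46 log units; beyond the scatter) expected. Compound 4 is estimated at 15000 nM, within 5000 nM to 45000 nM.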

Compound 4, half-maximal inhibitory concentration: 17500 nM
Beside the measured number, compound 4's estimate is 1.2-fold (0.07 log units) below it; the measured number falls inside the stated range.
By their numbers in this assay, from the lowest: compounds 2 and 3 (each within the scatter of the next); then compound 4; then compound 1.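

In this assay one more chain carbon had changed nothing, yet cyclohexyl in place of hexyl brings a 3.4-fold higher number from compound 3 to compound 4 (0.53 log units; beyond the scatter) and cyclohexyl in place of pentyl brings a 3.4-fold higher number from compound 2 to compound 4 (0.54 log units; beyond the scatter) so at this place a modest loss comes with the ring rather than with chain length. With cyclohexylmethyl held constant, the methyl on the anilide ring gives a 2.3-fold lower number from compound 1 to compound 4 (0.37 log units; beyond the scatter) in the opposite direction. Whether a phenyl, a smaller cyclopentyl or a chain ending in an amine would match cyclohexyl or the open chains remains open, and no measurement offers a reason for these steps.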